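Metabolic Stability Across Two Related Ester Variants

This account rests on a few compounds, and the source may have more. Where it says the series, first, only, none or still open, it means among the compounds named here.

Compound 1 `CC(C)OC(=O)c1cccc(NC(=O)[C@@H]2C[C@H](SC3=C(C(=O)O)N4C(=O)[C@H]([C@@H](C)O)[C@H]4[C@H]3C)CN2)c1` and compound 2 `CC(C)C(=O)OCOC(=O)c1cccc(NC(=O)[C@@H]2C[C@H](SC3=C(C(=O)O)N4C(=O)[C@H]([C@@H](C)O)[C@H]4[C@H]3C)CN2)c1` share one core and differ only by ((isopropylcarbonyl)oxy)methyl in place of isopropyl on an oxygen next to a carbonyl group. In an ADME assay for metabolic stability, read by LC-MS, with a stated time of 3 h, at pH 6.5, tested at 50 uM (a lower number here means that less of the compound is left, a higher number that more of the compound is left), compound 1 gives > 95%, which is a limit of the assay and not a number. Compound 2 gives > 95% in this assay, again a limit. The step between them is therefore a step that the two limits leave unreadable from compound 1 to compound 2. Compound 3 `CC(C)OC(=O)C1=C(S[C@@H]2CN[C@H](C(=O)Nc3cccc(C(=O)O)c3)C2)[C@H](C)[C@@H]2[C@@H]([C@@H](C)O)C(=O)N12` is built from the same atoms as compound 1, joined differently, and the difference between the two cores is not broken down here. In this assay compound 3 gives > 95%, once more a limit. All three values sit at the limit of > 95% in this assay, at which 3 of the 3 values shown sit. Compound 4 `CC(C)C(=O)OCOC(=O)C1=C(S[C@@H]2CN[C@H](C(=O)Nc3cccc(C(=O)O)c3)C2)[C@H](C)[C@@H]2[C@@H]([C@@H](C)O)C(=O)N12`, not yet measured, differs from compound 3 by ((isopropylcarbonyl)oxy)methyl in place of isopropyl on an oxygen next to a carbonyl group, the same change that was made from compound 1 to compound 2, occurring twice among these compounds. Compound 4 is expected to give 96% in this assay, estimated to fall between 88% and 100%, so that the expected step is a step that the limit leaves unreadable from compound 3 to compound 4. This expectation rests on compound 2, which gives > 95% in this assay after the same change.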

Compound 4, percent of the compound remaining in the ADME assay: > 95%
Compound 4 gave a limit, no number (the forecaster's own chance of this, stated with the estimate: 85%); the middle value is on the limit's open side.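

Compound 3 and compound 4 give only limits, not numbers, in the ADME assay. In a physicochemical assay for metabolic stability, read by LC-MS, in phosphate buffer, with a stated time of 3 h, at pH 7.4, tested at 50 uM (a higher number here means that more of the compound is left, a lower number that less of the compound is left), compound 3 gives > 95%, which is a limit of the assay and not a number. In the physicochemical assay compound 4 gives > 95%, again a limit of the assay and not a number. Going by these compounds alone, no step between them can be read in either case. The compounds shown leave open whether ((isopropylcarbonyl)oxy)methyl in place of isopropyl changes the percent of compound remaining in the ADME assay or in the physicochemical assay.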